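Shortening the Chain on Compound 3 by Two Carbons

The compounds below may be only part of what the source reports. "The series", "measured", "known", "first", "only" and "open" are said of these compounds alone.

Three close analogues have been run in a functional assay on HeLa cells (Homo sapiens) for cytotoxicity, read by microscopy (on this read-out higher numbers stand for lower toxicity in this test and lower numbers for higher toxicity in this test), all sharing one core and differing only in the length of a saturated chain attached to an aromatic carbon. Compound 1 `CCCc1ccc(-c2cc3cn([C@H]4C[C@H](O)[C@@H](CO)O4)c(=O)nc3s2)cc1` gives 80000 nM in this assay. Compound 2 `CCCCc1ccc(-c2cc3cn([C@H]4C[C@H](O)[C@@H](CO)O4)c(=O)nc3s2)cc1` gives 50000 nM in this assay. The move from the shorter to the longer chain, methyl in place of hydrogen on a saturated chain carbon, three bonds along the chain from an aromatic carbon, gave a 1.6-fold lower number from compound 1 to compound 2 (0.20 log units; within the scatter). Compound 3 `CCCCCCCCc1ccc(-c2cc3cn([C@H]4C[C@H](O)[C@@H](CO)O4)c(=O)nc3s2)cc1` gives only a limit in this assay, >= 20000 nM. The steps a step that the limit leaves unreadable from compound 1 to compound 3 and a step that the limit leaves unreadable from compound 2 to compound 3 cannot be sized because of the limit of >= 20000 nM in this assay, at which 1 of the 3 values shown sits.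

Compound 4 `CCCCCCc1ccc(-c2cc3cn([C@H]4C[C@H](O)[C@@H](CO)O4)c(=O)nc3s2)cc1` differs from compound 3 by hydrogen in place of ethyl on a saturated chain carbon, six bonds along the chain from an aromatic carbon. Within the data shown here, the single readable step among the chain changes lay within the scatter, and the two steps to compound 3 show no size at all, so no shift beyond the scatter is expected, and a limit rather than a number is quite possible. Compound 4 is therefore estimated to give 30000 nM in this assay, between 12000 nM and 80000 nM. The expected step is a step that the limit leaves unreadable from compound 3 to compound 4.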

Compound 4, minimum cytotoxic concentration: 200000 nM
Beside the measured number, compound 4's estimate is 6.7-fold (0.82 log units) below it; the measured number lies above the stated range.
By their numbers in this assay, from the lowest: compounds 2 and 1 (each within the scatter of the next); then compound 4.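

In this assay, the chain of compound 4 moves the number beyond the scatter, giving a 4.0-fold higher number from compound 2 to compound 4 (0.60 log units; beyond the scatter) and a 2.5-fold higher number from compound 1 to compound 4 (0.40 log units; beyond the scatter). Higher numbers mean lower toxicity in this test, so a chain change at this position can shift the read-out, which the one readable step among the earlier compounds did not show. The steps from compounds 1, 2 and 4 to compound 3 cannot be read because of a limit: the limit of >= 20000 nM in this assay, at which 1 of the 4 values shown sits.

Going by these compounds, it therefore stays open whether adding the ethyl to compound 4 keeps, raises or reverses this shift. The compounds shown also leave open what an amine or a carboxylic acid would do in place of that ethyl, on the same saturated chain carbon.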